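The source may hold more compounds than are shown below. What is called first, only, known or untested is meant among the compounds shown, and "the series" means these compounds.

Three compounds share one core and differ only in the group carried on the amine nitrogen in the ring. In a functional assay on A549 cells (Homo sapiens) for inhibition, read by MTT assay, with a stated time of 72 h (on this read-out higher numbers stand for weaker inhibition and lower numbers for stronger inhibition), compound 1 `COc1ccc(N2CCN(C(=S)N/N=C3\C(=O)Nc4ccc(Cl)cc43)CC2)cc1` gives 7680 nM. Compound 2 `O=C1Nc2ccc(Cl)cc2/C1=N/NC(=S)N1CCN(c2ccccc2Cl)CC1` gives 7920 nM in this assay, and compound 3 `O=C1Nc2ccc(Cl)cc2/C1=N/NC(=S)N1CCN(c2ccc(Cl)c(Cl)c2)CC1` gives 7950 nM. Compound 3 sits within the scatter of both others: the steps of a 1.0-fold higher number from compound 1 to compound 2 (0.01 log units; within the scatter), a 1.0-fold higher number from compound 1 to compound 3 (0.02 log units; within the scatter) and a 1.0-fold higher number from compound 2 to compound 3 (0.00 log units; within the scatter) were all flat. Compound 4 `O=C1Nc2ccc(Cl)cc2/C1=N/NC(=S)N1CCN(c2ccc([N+](=O)[O-])cc2)CC1` makes a fourth exchange at the same place: 4-nitrophenyl in place of 3,4-dichlorophenyl on an amine nitrogen in a ring. All three measured exchanges at that nitrogen bear on it, and none moved this assay beyond the scatter, so no step beyond the scatter is expected here either. The expected step is a 1.0-fold lower number from compound 3 to compound 4 (0.00 log units; within the scatter). Compound 4 is estimated at 7900 nM in this assay, with a range from 4000 nM to 16000 nM.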

Compound 4, half-maximal inhibitory concentration: 11800 nM
Estimate against measurement, compound 4: 1.5-fold (0.17 log units) below; measured number inside the range.
By their numbers in this assay, from the lowest: compounds 1, 2, 3 and 4 (each within the scatter of the next).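

The 4-nitrophenyl group brings a double bond outside aromatic rings and hydrogen-bond acceptors to the amine nitrogen in the ring, yet every new step in this assay stays within the scatter: a 1.5-fold higher number from compound 3 to compound 4 (0.17 log units; within the scatter) and a 1.5-fold higher number from compound 2 to compound 4 (0.17 log units; within the scatter) and a 1.5-fold higher number from compound 1 to compound 4 (0.19 log units; within the scatter). The last of these is a direct exchange of nitro for methoxy on an aromatic carbon, and the four aryl groups at this nitrogen cannot be told apart on this read-out. No evidence bears on this result.

From the compounds shown here alone, whether an amine or a carboxylic acid on the phenyl ring would move this read-out remains open. So does the replacement of the aryl group by a longer chain.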